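The source may report more compounds than this note shows. Statements on the series, on what has been measured and on what is new or still open speak of the compounds shown alone.

Measured so far:

Compound 1, `CCCCc1c(OC)nc2nc(C(=O)c3ccccc3)cn2c1CC`: in a functional assay on the whole organism with Rattus norvegicus as the target (a lower number here means that less compound is needed, a higher number that more compound is needed for the effect), compound 1 gives 10 mg/kg.
Compound 2, `CCCCc1c(OC)nc2nc(C(=O)c3ccccc3)cn2c1C`: in this assay compound 2 gives 2 mg/kg.
Compound 3, `C=CCc1c(OC)nc2nc(C(=O)c3ccccc3)cn2c1CC`: in this assay compound 3 gives 10 mg/kg.

Compound 4, `C=CCc1c(OC)nc2nc(C(=O)c3ccccc3)cn2c1C`, has not yet been measured in this assay. It is related to compound 3 in the same way that compound 2 is related to compound 1. Between compound 1 and compound 2 the change is hydrogen in place of methyl on a saturated chain carbon bound to an aromatic carbon, and this single change brought a 5.0-fold lower number from compound 1 to compound 2 (0.70 log units; beyond the scatter). Between compound 3 and compound 4 the change is hydrogen in place of methyl on a saturated chain carbon bound to an aromatic carbon, sitting at the same place, so it is the same change.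

The two cores differ as well: compound 3 is set apart from compound 1 by vinyl in place of propyl on a saturated chain carbon bound to an aromatic carbon, and that swap gave no change at the digits printed from compound 1 to compound 3 (within the scatter). Since this core difference left the number essentially unchanged, the earlier step is the best guide. Compound 4 is expected to show a 5.0-fold lower number from compound 3 to compound 4 (0.70 log units; beyond the scatter), resting on the drop seen in a 5.0-fold lower number from compound 1 to compound 2 (0.70 log units; beyond the scatter). Compound 4 is therefore estimated at 2 mg/kg, most likely between 1 mg/kg and 5 mg/kg.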

Compound 4, minimum effective dose: 5 mg/kg
For compound 4 the middle estimate is 2.5-fold (0.40 log units) below the measured one; the measured number falls inside the stated range.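

In this assay, going from ethyl to methyl on the core of compound 3 gives a 2.0-fold lower number from compound 3 to compound 4 (0.30 log units; within the scatter), and this step does not differ measurably from the one seen on the core of compound 1: the same change on two cores in this assay, a 5.0-fold lower number (0.70 log units; beyond the scatter) from compound 1 to compound 2 and a 2.0-fold lower number (0.30 log units; within the scatter) from compound 3 to compound 4, 2.5-fold (0.40 log units) apart, within the scatter of two such steps. The swap of propyl for vinyl, read on the methyl-bearing pair, gives a 2.5-fold higher number from compound 2 to compound 4 (0.40 log units; beyond the scatter), and it likewise agrees with its earlier counterpart: the same change on two cores in this assay, no change at the digits printed (within the scatter) from compound 1 to compound 3 and a 2.5-fold higher number (0.40 log units; beyond the scatter) from compound 2 to compound 4, 2.5-fold (0.40 log units) apart, within the scatter of two such steps. For the compounds shown here, nothing here shows either change behaving differently on the two cores, but this does not prove that they behave identically, since the step from ethyl to methyl on the core of compound 3 cannot by itself be told from scatter and only two cores are compared.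

The compounds shown leave open what a longer chain or an amine would do where ethyl and methyl sit. They also leave open whether either change would carry over to a core bearing a different group, such as a carboxylic acid.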